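The source may hold more compounds than are shown below. What is called first, only, known or untested is meant among the compounds shown, and "the series" means these compounds.

In a functional assay on MDA-MB-231 cells (Homo sapiens) for antiproliferative activity, read by MTT assay, with a stated time of 72 h (on this read-out lower numbers stand for stronger inhibition and higher numbers for weaker inhibition), compound 1 `COc1cc(OC)cc(-c2cccc(NC(=O)CCc3cccc4c3B(O)OC4)c2)c1` gives 40 nM, while compound 2 `COc1cccc(-c2cccc(NC(=O)CCc3ccc4c(c3)COB4O)c2)c1` gives 90000 nM, the higher of the two numbers and well beyond the scatter. Compound 3 `COc1cc(OC)cc(-c2cccc(NC(=O)CCc3ccc4c(c3)COB4O)c2)c1` follows from compound 2 by methoxy in place of hydrogen on an aromatic carbon, turning 3-methoxyphenyl into 3,5-dimethoxyphenyl. A large fall in the number is expected in this assay, estimated as a 45-fold lower number from compound 2 to compound 3 (1.65 log units; beyond the scatter). This expectation rests on compound 1, which carries 3,5-dimethoxyphenyl and gives 40 nM. Going by the values given here, with only two measured compounds, the uncertainty is wide. The estimate for compound 3 is 2000 nM, within an expected range of 150 nM to 30000 nM.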

Compound 3, half-maximal inhibitory concentration: 77000 nM
The estimate for compound 3 lay 39-fold (1.59 log units) below the measured number; measured number outside the range, above it.
By their numbers in this assay, from the lowest: compound 1; then compounds 3 and 2 (each within the scatter of the next).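

In this assay, methoxy in place of hydrogen on the aromatic carbon gives a 1.2-fold lower number from compound 2 to compound 3 (0.07 log units; within the scatter), so 3,5-dimethoxyphenyl on the core of compound 2 leaves the number far from that of compound 1. With 3,5-dimethoxyphenyl held constant, exchanging the group on the saturated chain carbon gives a 1900-fold higher number from compound 1 to compound 3 (3.28 log units; beyond the scatter), placing the large gap with that exchange rather than with the methoxy. Nothing on hand explains this gap.

Still open, as far as these compounds go, is how 3-methoxyphenyl behaves on the core of compound 1. Also open, from the compounds shown here alone, is whether an amine or a carboxylic acid in place of methoxy moves the number on either core.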